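The compounds below may be only part of what the source reports. "The series", "measured", "known", "first", "only" and "open" are said of these compounds alone.

Measured so far, in an assay for inhibition of Catechol O-methyltransferase (Rattus norvegicus), read by fluorescence and spectrophotometry; on this read-out higher numbers stand for weaker inhibition and lower numbers for stronger inhibition:

- compound 1 `O=C(/C=C/c1ccsc1)c1cc(O)c(O)c([N+](=O)[O-])c1`: 230 nM
- compound 2 `O=C(/C=C/c1ccoc1)c1cc(O)c(O)c([N+](=O)[O-])c1`: 290 nM
- compound 3 `O=C(/C=C/c1cccs1)c1cc(O)c(O)c([N+](=O)[O-])c1`: 190 nM

Compound 3 holds the lowest of the three numbers, but both steps to it, a 1.2-fold lower number from compound 1 to compound 3 (0.08 log units; within the scatter) and a 1.5-fold lower number from compound 2 to compound 3 (0.18 log units; within the scatter), are within the scatter, so the three compounds are not separated on this read-out.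

Compound 4 `O=C(/C=C/c1ccco1)c1cc(O)c(O)c([N+](=O)[O-])c1` differs from compound 3 by furan-2-yl in place of thiophen-2-yl on a double-bonded chain carbon bound to a double-bonded chain carbon. Within the data shown here, the one measured step that bears on this exchange is the same swap of oxygen for sulfur on the other attachment position of the five-membered ring, a 1.3-fold higher number from compound 1 to compound 2 (0.10 log units; within the scatter), which stayed within the scatter. The step of a 1.3-fold higher number from compound 3 to compound 4 (0.10 log units; within the scatter) is therefore expected to be of about that size, a slightly higher number at most and nothing beyond the scatter. Compound 4 is accordingly estimated at 240 nM, with a range of 120 nM to 480 nM in this assay.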

Compound 4, half-maximal inhibitory concentration: 230 nM
Beside the measured number, compound 4's estimate is 1.0-fold (0.02 log units) above it; measured number inside the range.
By their numbers in this assay, from the lowest: compounds 3, 1, 4 and 2 (each within the scatter of the next).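

In this assay the steps of a 1.2-fold higher number from compound 3 to compound 4 (0.08 log units; within the scatter) and a 1.3-fold lower number from compound 2 to compound 4 (0.10 log units; within the scatter) and no change at the digits printed from compound 1 to compound 4 (within the scatter) all lie within the scatter. Oxygen for sulfur now reads the same way for thiophen-2-yl to furan-2-yl as for thiophen-3-yl to furan-3-yl, and furan-2-yl is not separated from furan-3-yl. None of the four five-membered aromatic rings at this place is separated from the others. Still open, from the compounds shown here alone, is whether a phenyl ring, an amine or a longer chain at this place would move the number beyond the scatter. No measurement here bears on why these rings read alike.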